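Adding fluoromethyl to compound 2: what to expect

The source may report more compounds than this note shows. Statements on the series, on what has been measured and on what is new or still open speak of the compounds shown alone.

Compounds measured so far in a physicochemical assay for lipophilicity, read by HPLC, in phosphate buffer, measured as octanol-water partition, with a stated time of 1 h, at pH 7.4; on this read-out higher numbers stand for higher lipophilicity and lower numbers for lower lipophilicity
Compound 1 `N#Cc1ccc(C(=O)Nc2ccc(F)c([C@]3(C4CC4)C=C(CF)OC(N)=N3)c2)nc1` gives 2.9
Compound 2 `C[C@@]1(c2cc(NC(=O)c3ccc(C#N)cn3)ccc2F)C=COC(N)=N1` gives 2

Compound 2 stands lowest of these two at 2 and the gap up to compound 1 lies beyond the usual scatter. Compound 3 `C[C@@]1(c2cc(NC(=O)c3ccc(C#N)cn3)ccc2F)C=C(CF)OC(N)=N1` differs from compound 2 in one place (fluoromethyl in place of hydrogen on a double-bonded ring carbon) with fluoromethyl in place of hydrogen on a double-bonded ring carbon. Compound 1 carries fluoromethyl on that carbon too and gives 2.9 but it also differs from compound 3 at the ring atom that bears a methyl group, so only part of that gap is expected to carry over. In this assay a modest rise is expected, estimated as a number 0.40 log units higher from compound 2 to compound 3 (beyond the scatter) and so just beyond the scatter. The estimate for compound 3 is 2.4 with an expected range from 2.1 to 2.8 for the measurement.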

Compound 3, distribution coefficient: 2.3
The estimate for compound 3 lay 0.10 log units above the measured number; the measured number falls inside the stated range.
By their numbers in this assay, from the lowest: compounds 2 and 3 (each within the scatter of the next); then compound 1.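

In this assay, fluoromethyl in place of hydrogen on a double-bonded ring carbon gives a number 0.30 log units higher from compound 2 to compound 3 (within the scatter), so at this position the change cannot be told apart from the variation between repeated measurements. The step that clears that scatter lies at the other site: methyl in place of cyclopropyl on a saturated ring carbon gives a number 0.60 log units lower from compound 1 to compound 3 (beyond the scatter). Nothing available explains why either step has the size it has.

As far as these compounds go, it remains open whether a different group on the double-bonded ring carbon, such as an amine, a carboxylic acid or a longer chain, would shift the number beyond the scatter. Also open, from the compounds shown here alone, is whether fluoromethyl in place of hydrogen would give a similar step with cyclopropyl on the saturated ring carbon.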